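A few compounds are considered here, and "the series" means these few. Any claim that something is new, unique, unknown or untested is made for them only; others in the source may bear on it.

Measured so far in a functional assay on JeKo-1 cells (Homo sapiens) for antiproliferative activity; on this read-out lower numbers stand for stronger inhibition and higher numbers for weaker inhibition:
compound 1 `Nc1ncnc2c1c(-c1ccc(Oc3ccccc3)cc1)cn2[C@H]1CCN(C[C@H]2CO2)C1` gives 5080 nM
compound 2 `CC(C)(C)c1ccc(C(=O)Nc2cccc(-c3cn([C@H]4CCN(C[C@@H]5CO5)C4)c4ncnc(N)c34)c2)cc1` gives 2540 nM
compound 3 `Nc1ncnc2c1c(-c1ccc(Oc3ccccc3)cc1)cn2C[C@H]1CCCN1C[C@@H]1CO1` gives 11100 nM

Compound 3 has the highest number of the three; compound 1 sits nearest, compound 2 furthest. The change to compound 4 `Nc1ncnc2c1c(-c1ccc(Oc3ccccc3)cc1)cn2[C@H]1CCN(C[C@@H]2CO2)C1` is 1-((oxiran-2-yl)methyl)pyrrolidin-3-yl in place of (1-((oxiran-2-yl)methyl)pyrrolidin-2-yl)methyl on an aromatic nitrogen. Within the data shown here, the one step that bears on it, a 2.2-fold higher number from compound 1 to compound 3 (0.34 log units; beyond the scatter), ran the other way and was modest. Compound 4 differs from compound 1 only in the configuration at one stereocentre of the entering group, and nothing measured tells how that configuration matters. The step is therefore expected to roughly reverse the earlier one, the number of compound 4 expected to fall by a 2.2-fold lower number from compound 3 to compound 4 (0.35 log units; beyond the scatter) in this assay. Compound 4 is estimated at 5000 nM, range 2500 nM to 10000 nM.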

Compound 4, half-maximal inhibitory concentration: 1480 nM
Compound 4: the middle estimate sits 3.4-fold (0.53 log units) above what was measured; measured number outside the range, below it.
By their numbers in this assay, from the lowest: compounds 4, 2 and 1 (each within the scatter of the next, the first and the last beyond it); then compound 3.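

In this assay a single stereocentre at a saturated ring carbon carries a step of its own (a 3.4-fold lower number from compound 1 to compound 4 (0.54 log units; beyond the scatter)), and that step can be put down to configuration alone: the fact that compounds 1 and 4 differ only in the configuration as drawn. With this configuration the 1-((oxiran-2-yl)methyl)pyrrolidin-3-yl group stands further from the (1-((oxiran-2-yl)methyl)pyrrolidin-2-yl)methyl group of compound 3 (a 7.5-fold lower number from compound 3 to compound 4 (0.88 log units; beyond the scatter)), so the size of this change depends on the configuration as drawn.

Open, going by these compounds, is how an acrylamide or a plain methyl would compare with the (oxiran-2-yl)methyl part of the group. Also open, on these data alone, is whether the configuration step carries over to other groups on the core.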